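A few compounds are considered here, and "the series" means these few. Any claim that something is new, unique, unknown or untested is made for them only; others in the source may bear on it.

Series notes. The shared core carries an oxypropyl link to a substituted phenyl, and compound 1 `NC1=NC2(CCSCC2)N(OCCCOc2cccc(Cl)c2Cl)C(N)=N1`, compound 2 `NC1=NC2(CCSCC2)N(OCCCOc2ccc(Cl)cc2)C(N)=N1` and compound 3 `NC1=NC2(CCSCC2)N(OCCCOc2ccc(Br)cc2)C(N)=N1` differ only in that phenyl. In an assay on isolated protein for inhibition of Dihydrofolate reductase (Homo sapiens), read by spectrophotometry, using NADPH, with stated times of 5 s and 6 min, tested at 5 uM (on this read-out higher numbers stand for a stronger effect at the one concentration tested and lower numbers for a weaker effect), compound 1 gives 83.8%. Compound 2 reaches a limit of the read-out, > 90%, which is not a number. Compound 3 likewise reaches a limit, > 90%, and no number. The steps of a number at least 6.2 percentage points higher from compound 1 to compound 2 (that floor lies within the scatter) and a number at least 6.2 percentage points higher from compound 1 to compound 3 (that floor lies within the scatter) are therefore floors only, and the step that the two limits leave unreadable from compound 2 to compound 3 cannot be read because of the limit of > 90% in this assay, at which 2 of the 3 values shown sit. Among the compounds with values here, compound 3 thus stands at the edge of what this assay shows, with compound 2 at the same limit and compound 1 the only one with a read number. Compound 4 `CC(C)(C)c1ccc(OCCCON2C(N)=NC(N)=NC23CCSCC3)cc1` differs from compound 3 by tert-butyl in place of bromo on an aromatic carbon. Within the data shown here, no measured step exchanges a halogen for an alkyl group; the one measured step on that aromatic carbon is unreadable, so nothing here sets the size of this change. The expectation for compound 4 in this assay is 85%, between 68% and 95%. The expected step of a number at least 5 percentage points lower from compound 3 to compound 4 (that floor lies within the scatter) is taken as within the scatter, with a real chance that compound 4 again reports only a limit.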

Compound 4, a percentage reported as inhibition, at one concentration (the size of the read-out at that concentration, not a potency): 85.3%
Beside the measured number, compound 4's estimate is 0.3 percentage points below it; the range from low to high includes it.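

With tert-butyl on the aromatic carbon para to a large group, compound 4 gives a read number in this assay, 85.3%, so this position now has a substituent with a value that can be read as a number. The exchange of halogen for tert-butyl gives a number at least 4.7 percentage points lower from compound 3 to compound 4 (that floor lies within the scatter), and likewise a number at least 4.7 percentage points lower from compound 2 to compound 4 (that floor lies within the scatter), so neither floor establishes a real loss, and a group much larger than bromo or chloro is accepted here with the read-out still high. These steps remain floors, and the step from chloro to bromo cannot be read at all, because the halogen compounds give no numbers: the limit of > 90% in this assay, at which 2 of the 4 values shown sit.

On these data alone, the true gap between the halogens and tert-butyl remains open. Also open, as far as these compounds go, is how this aromatic carbon responds to an amine, a carboxylic acid or a methoxy group in place of these substituents.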